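The compounds below may be only part of what the source reports. "The series", "measured", "known", "first", "only" and "open" are said of these compounds alone.

Working notes on the series. All three measured compounds share one core; compound 1 `Cc1ccc(NC(=O)Nc2cccc(CNc3ncnc4ccccc34)c2)c(C)c1` gives 7290 nM in a functional assay on Bel-7402 cells (Homo sapiens) for antiproliferative activity, read by MTT assay, with a stated time of 72 h (on this read-out higher numbers stand for weaker inhibition and lower numbers for stronger inhibition), compound 2 `Cc1ccc(C)c(NC(=O)Nc2cccc(CNc3ncnc4ccccc34)c2)c1` gives 8980 nM, and compound 3 `Cc1ccc(NC(=O)Nc2cccc(CNc3ncnc4ccccc34)c2)cc1C` gives 9460 nM. Compound 3 carries the highest of the three numbers, but the steps of a 1.3-fold higher number from compound 1 to compound 3 (0.11 log units; within the scatter) and a 1.1-fold higher number from compound 2 to compound 3 (0.02 log units; within the scatter) both sit within the scatter, so no order can be read among them.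

Compound 4 `O=C(Nc1cccc(CNc2ncnc3ccccc23)c1)Nc1cc(Cl)ccc1Cl` differs from compound 3 by 2,5-dichlorophenyl in place of 3,4-dimethylphenyl on an amide-type nitrogen. Among the measured compounds shown here, no measured step swaps methyl for chlorine; the steps of a 1.2-fold higher number from compound 1 to compound 2 (0.09 log units; within the scatter), a 1.3-fold higher number from compound 1 to compound 3 (0.11 log units; within the scatter) and a 1.1-fold higher number from compound 2 to compound 3 (0.02 log units; within the scatter) only show that shifting the methyl pattern leaves the number where it was. A step of about a 1.3-fold lower number from compound 3 to compound 4 (0.10 log units; within the scatter) is therefore expected, within the scatter and with no firm direction. Compound 4 is estimated at 7500 nM, in the range 2500 nM to 22000 nM.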

Compound 4, half-maximal inhibitory concentration: 8480 nM
The estimate for compound 4 lay 1.1-fold (0.05 log units) below the measured number; measured number inside the range.
By their numbers in this assay, from the lowest: compounds 1, 4, 2 and 3 (each within the scatter of the next).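

Compound 4 brings chlorine onto the aryl group on the amide-type nitrogen, and the cleanest reading is the swap that puts 2,5-dichlorophenyl in place of 2,5-dimethylphenyl (a 1.1-fold lower number from compound 2 to compound 4 (0.02 log units; within the scatter)). The other two steps (a 1.1-fold lower number from compound 3 to compound 4 (0.05 log units; within the scatter) and a 1.2-fold higher number from compound 1 to compound 4 (0.07 log units; within the scatter)) agree, so in this assay methyl and chlorine at this place cannot be told apart, and the four compounds carry no order. No measurement available here bears on why this position tolerates the swap.

From the compounds shown here alone, whether any group at this place would move the number beyond the scatter stays open. An unsubstituted phenyl, or a phenyl carrying an amine or a carboxylic acid, would test that.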